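The source may hold more compounds than are shown below. What is called first, only, known or untested is meant among the compounds shown, and "the series" means these compounds.

Compound 1 `CC(C)=CCC[C@]1(C)/C=C/[C@@H](OC(=O)C=C(C)C)[C@](C)(O)/C=C/[C@H](O)/C(CO)=C\C1`: > 40000 nM
Compound 2 `CO[C@@H]1/C=C/[C@@](C)(O)[C@H](OC(=O)C=C(C)C)/C=C/[C@@](C)(CCC=C(C)C)C/C=C\1CO`: 13800 nM

Within the data shown here, only two values are known so far, both from a functional assay on HL-60 cells (Homo sapiens) for antiproliferative activity, read by MTT assay, with a stated time of 48 h; on this read-out lower numbers stand for stronger inhibition and higher numbers for weaker inhibition. In this assay, among the measured compounds shown here, compound 2 gives 13800 nM, and this is the only true number available. Compound 1 gives > 40000 nM, which is a limit of the assay and not a number.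

The next compound to be tested is compound 3 `CO[C@H]1/C=C/[C@@](C)(O)[C@H](OC(=O)C=C(C)C)/C=C/[C@@](C)(CCC=C(C)C)C/C=C\1CO`, and it is a very close relative of compound 2. The change is the two compounds have the same atoms and bonds and differ only in configuration as drawn: 1 of 7 stereo elements differ; a stereocentre at a saturated ring carbon is drawn R in compound 2 and S in compound 3. Nothing is added or removed, so the question is only whether this one change of configuration matters in this assay.

For the measured compounds named here, no two measured compounds differ in just one place, so the data give no direct guide to the size of such a step. The expectation therefore starts from compound 2 at 13800 nM, with no step beyond the usual scatter and no firm direction. The expected change is a 1.2-fold higher number from compound 2 to compound 3 (0.06 log units; within the scatter). For compound 3 the estimated value is 16000 nM, with an expected range of 6000 nM to 36000 nM.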

Compound 3, half-maximal inhibitory concentration: 14900 nM
Estimate against measurement, compound 3: 1.1-fold (0.03 log units) above, within the range that was stated.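

Compound 3 tests this position directly, giving a 1.1-fold higher number from compound 2 to compound 3 (0.03 log units; within the scatter) in this assay, and this step reads on configuration alone: the fact that compounds 2 and 3 differ only in the configuration as drawn. With a methyl on the oxygen, then, swapping R for S at this saturated ring carbon produces no change that can be told apart from the scatter of repeated measurements. The other new step, methyl in place of hydrogen on an oxygen on a saturated carbon, gives an at least 2.6-fold lower number from compound 1 to compound 3 (0.42 log units; beyond the scatter), so this small change registers where the change of configuration does not, although its true size stays unknown because compound 1 sits at a limit and not at a number: the limit of > 40000 nM in this assay, at which 1 of the 3 values shown sits.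

The compounds shown leave open whether configuration would stay just as silent with a larger group on this oxygen, such as an ethyl ether, a benzyl ether or an acetate ester. They also leave open how an amine in place of this oxygen would behave, and whether the drawn configuration matters when the oxygen carries hydrogen, as in compound 1.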